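Diethylamino for isopropyl on a lipopeptide amide

This account rests on a few compounds, and the source may have more. Where it says the series, first, only, none or still open, it means among the compounds named here.

Measured so far in an assay on HEK293 cells for agonist activity at Toll-like receptor 2 (Homo sapiens); a lower number here means that less compound is needed, a higher number that more compound is needed for the effect:
compound 1, `CCCCCCCCCCCC(=O)OC[C@H](CSC[C@@H](N)C(=O)NC1(CO)CC1)OC(=O)CCCCCCCCCCC`, gives 265 nM;
compound 2, `CCCCCCCCCCCC(=O)OC[C@H](CSC[C@@H](N)C(=O)NC(C)CCC(C)C)OC(=O)CCCCCCCCCCC`, gives 190 nM;
compound 3, `CCCCCCCCCCCC(=O)OC[C@H](CSC[C@@H](N)C(=O)NCCOCCOCCOCCC(=O)O)OC(=O)CCCCCCCCCCC`, gives 900 nM.

Compound 2 stands at the lowest of the three numbers, though its gap to compound 1 is within the scatter, so no order between those two can be read. Only compound 3, with its chain ending in a carboxylic acid, sits beyond the scatter above compound 2.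

Compound 4, `CCCCCCCCCCCC(=O)OC[C@H](CSC[C@@H](N)C(=O)NC(C)CCN(CC)CC)OC(=O)CCCCCCCCCCC`, differs from compound 2 at a single place: diethylamino in place of isopropyl on a saturated chain carbon, three bonds along the chain from an amide-type nitrogen. Going by the values given here, the one step measured, a 1.4-fold lower number from compound 1 to compound 2 (0.14 log units; within the scatter), swaps the whole group on the amide-type nitrogen and says little about a diethylamino in place of an isopropyl further along the chain. Among the compounds with values here, the pair compound 2 and compound 3 shows that a long polar chain on that nitrogen gives a higher number, but no measured step introduces an amine. He therefore expects a modest rise in this assay, a 1.7-fold higher number from compound 2 to compound 4 (0.23 log units; within the scatter), with wide uncertainty. His estimate for compound 4 is 320 nM, ranging from 120 nM to 900 nM.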

Compound 4, half-maximal effective concentration: 257 nM
Compound 4: middle estimate off by 1.2-fold (0.10 log units), on the high side; low and high end bracket the measured number.
By their numbers in this assay, from the lowest: compounds 2, 4 and 1 (each within the scatter of the next); then compound 3.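

In this assay, the step (a 1.4-fold higher number from compound 2 to compound 4 (0.13 log units; within the scatter)) shows that diethylamino can replace isopropyl on this saturated chain carbon, three bonds along the chain from an amide-type nitrogen, with no difference that can be read beyond the scatter. The wider exchange of the whole group on that nitrogen (a 1.0-fold lower number from compound 1 to compound 4 (0.01 log units; within the scatter)) also stays within the scatter, so 3-(diethylamino)-1-methylpropyl and 1-(hydroxymethyl)cyclopropyl cannot be told apart in this assay. No supporting measurement is available to explain these results.

From the compounds shown here alone, whether dimethylamino, piperidine or a carboxylic acid at this same place would also stay within the scatter of compound 2 remains open. So does the outcome of a longer chain carrying the diethylamino.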